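Benzyl ring chloro substitution in the series

The source may report more compounds than this note shows. Statements on the series, on what has been measured and on what is new or still open speak of the compounds shown alone.

Of the compounds shown here, three of the shared core have been measured in a functional assay on the whole organism (artery, strain albino) with Rattus norvegicus as the target, with a stated time of 180 min, at a dose of 10 mg/kg by the oral route; a lower number here means less inhibition, a higher number more inhibition at the dose given (going by the name of the read-out). Compound 1 `COc1ccc(C2N=C(SCc3cccc(Cl)c3)NC(C)=C2C(=O)Nc2ccc(F)cc2)cc1OC` gives 13.4%. Compound 2 `COc1ccc(C2N=C(SCc3ccc(F)cc3)NC(C)=C2C(=O)Nc2ccc(F)cc2)cc1OC` gives 22.2%. Compound 3 `CC1=C(C(=O)Nc2ccc([N+](=O)[O-])cc2)C(c2ccc(Br)cc2)N=C(SCc2ccccc2)N1` gives 19.6%, which stands second highest of the three numbers; its gap to compound 2 and its gap to compound 1 both fall within the scatter, so no order among the three can be read from these values.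

Compound 4 `CC1=C(C(=O)Nc2ccc([N+](=O)[O-])cc2)C(c2ccc(Br)cc2)N=C(SCc2ccccc2Cl)N1` is not yet measured. It differs from compound 3 by chloro in place of hydrogen on an aromatic carbon, the place being on an aromatic carbon of a six-membered aromatic ring of carbon only, ortho to a large group; read one bond further out, this is benzyl to 2-chlorobenzyl.

Among the compounds with values here, the only measured step on the same benzyl ring is a number 8.8 percentage points higher from compound 1 to compound 2 (within the scatter), where one halogenated benzyl is exchanged for another and the read-out stays within the scatter. A chloro entering this ring in compound 4 is therefore expected to give a step of a number 0.4 percentage points higher from compound 3 to compound 4 (within the scatter) that does not go beyond the scatter, in no firm direction. Compound 4 is accordingly estimated at 20%, with a range from 8% to 32%.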

Compound 4, a percentage reported as inhibition, in the whole organism at one dose (the size of the read-out at that dose, not a potency): 11.3%
Estimate against measurement, compound 4: 8.7 percentage points above; low and high end bracket the measured number.
By their numbers in this assay, from the lowest: compounds 4, 1, 3 and 2 (each within the scatter of the next, the first and the last beyond it).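

In this assay, within the data shown here, going from benzyl to 2-chlorobenzyl gives a number 8.3 percentage points lower from compound 3 to compound 4 (within the scatter), the first step read directly from the unsubstituted benzyl, and even this entry of a chloro on the ring does not move the number beyond the scatter. The earlier step on this ring exchanged one halogenated benzyl for another, whereas this one sets chloro against hydrogen with the rest of compound 3 held fixed; it therefore adds a direct reading at this place, though no firm direction. No measurement at hand bears on what lies behind the number at this position.

From the compounds shown here alone, it remains open whether a group of another kind on this benzyl ring, such as an amine or a carboxylic acid, or a longer chain in place of benzyl on the sulfur, would give a step beyond the scatter. It also remains open whether chloro in place of hydrogen at this place would read the same way with the other parts of compound 1 around it, as only one such pair is shown here.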